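This account rests on a few compounds, and the source may have more. Where it says the series, first, only, none or still open, it means among the compounds named here.

In a functional assay on CWR22R cells (Homo sapiens) for antiproliferative activity, read by propidium iodide staining, with a stated time of 96 h (a higher number here means a weaker inhibitor, a lower number a stronger inhibitor), compound 1 (`CC(O)(CSc1ccc(S(F)(F)(F)(F)F)cc1)C(=O)Nc1ccc([N+](=O)[O-])cc1C(F)(F)F`) gives 13100 nM and compound 2 (`CC(O)(CSc1cccc(S(F)(F)(F)(F)F)c1)C(=O)Nc1ccc(S(F)(F)(F)(F)F)cc1`) gives 17700 nM with no separation beyond the scatter. Compound 3 (`CC(O)(CSc1ccc(F)cc1)C(=O)Nc1ccc(S(F)(F)(F)(F)F)cc1`) at 13500 nM lies within the scatter of both, so the three values support no ranking. Compound 4 (`CC(O)(CSc1ccccc1C(F)(F)F)C(=O)Nc1ccc(S(F)(F)(F)(F)F)cc1`) carries 2-(trifluoromethyl)phenyl in place of 4-fluorophenyl on a sulfur. For the measured compounds named here, the series offers no measured step to size this change. With compound 3 at 13500 nM as the starting point, no step beyond the scatter is expected in this assay in either direction. For compound 4 the estimated value is 14000 nM (expected range 7000 nM to 30000 nM).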

Compound 4, half-maximal inhibitory concentration: 13200 nM
For compound 4 the middle estimate is 1.1-fold (0.03 log units) above the measured one; the measured number falls inside the stated range.
By their numbers in this assay, from the lowest: compounds 1, 4, 3 and 2 (each within the scatter of the next).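

In this assay, the group on the sulfur now has its first measured step: 2-(trifluoromethyl)phenyl in place of 4-fluorophenyl gives a 1.0-fold lower number from compound 3 to compound 4 (0.01 log units; within the scatter) and leaves the number unmoved beyond the scatter. In this single pair, the position accepts an entering group of 10 heavy atoms in place of one of 7 with no separable change. No measurement available here accounts for this result.

From the compounds shown here alone, whether a carboxylic acid, an amine or a longer chain in place of the phenyl ring would shift the number stays open. Also open, going by these compounds, is whether the same change behaves alike on the core of compound 1.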